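The source may report more compounds than this note shows. Statements on the series, on what has been measured and on what is new or still open speak of the compounds shown alone.

Measured so far:
Compound 1, `Cc1nn(C)c(Oc2ccc(Br)cc2)c1/C=N\CCCCCOc1cc2oc(=O)cc(C)c2cc1Cl`: 15300 nM
Compound 2, `Cc1nn(C)c(Oc2ccc(F)cc2F)c1/C=N\CCCCCCOc1cc2oc(=O)cc(C)c2cc1Cl`: > 25000 nM

Both were tested in a functional assay on U-87MG ATCC cells for antiproliferative activity against U-87 MG (Homo sapiens), read by MTT assay, with a stated time of 72 h; on this read-out higher numbers stand for weaker inhibition and lower numbers for stronger inhibition. Compound 1 gives 15300 nM, a weak result. Compound 2 gives only > 25000 nM, which is a limit of the assay and not a number. Going by the values given here, this is stated as the limit of > 25000 nM in this assay, at which 1 of the 2 values shown sits, so compound 2 stands at the edge of what this assay can report, and no step between compound 1 and compound 2 can be computed, since the two differ in more than one place.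

Compound 3, `Cc1nn(C)c(Oc2ccc(Br)cc2)c1/C=N\CCCCCCOc1cc2oc(=O)cc(C)c2cc1Cl`, has not yet been measured. It differs from compound 2 in one place: 4-bromophenyl in place of 2,4-difluorophenyl on an oxygen on an aromatic ring. Among the compounds with values here, the ring that enters is the one that compound 1 carries, while the chain stays that of compound 2.

Compound 1 stands at 15300 nM. Compound 2 is known only by a limit. Taken together, the step in this assay is expected to be small, at most within the usual scatter, with no clear direction. The expected step is an at least 1.2-fold lower number from compound 2 to compound 3 (0.09 log units; that floor lies within the scatter). Compound 3 is estimated at 20000 nM, within 8000 nM to 60000 nM.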

Compound 3, half-maximal inhibitory concentration: 5420 nM
For compound 3 the middle estimate is 3.7-fold (0.57 log units) above the measured one; measured number outside the range, below it.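

In this assay, going by these compounds alone, exchanging the 2,4-difluorophenyl for a 4-bromophenyl on the oxygen gives an at least 4.6-fold lower number from compound 2 to compound 3 (0.66 log units; beyond the scatter), the first step that can be read in this set, and it shows that the group at this place affects the result on the chain of compound 2. Compound 2 is known only by a limit of the assay and not by a number: the limit of > 25000 nM in this assay, at which 1 of the 3 values shown sits. The step is therefore a floor, so its direction is clear but its full size is not.

The change removes two fluorines and adds one bromine in a single move, so these compounds cannot show whether the 4-bromo group, the loss of the fluorines, or both account for the step; a plain phenyl, a 4-fluorophenyl or a 4-chlorophenyl on the same oxygen would help to separate these. On these data alone, it also remains open whether the 4-bromophenyl would hold up with a longer chain, or whether an amine or a carboxylic acid on that ring would be tolerated.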